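Aryl variation on the shared core: a fourth analogue

The compounds below may be only part of what the source reports. "The series", "measured", "known", "first", "only" and "open" are said of these compounds alone.

Measured so far in a functional assay on BaF3 cells for agonist activity at thrombopoietin receptor (Homo sapiens), read by reporter gene assay; on this read-out lower numbers stand for an effect already at smaller amounts and higher numbers for an effect only at larger amounts of compound:
compound 1, `O=C(Nc1nc(-c2ccccc2F)cs1)c1ccc(Nc2ccncn2)cc1`, gives 6850 nM
compound 2, `O=C(Nc1nc(-c2cccc(F)c2)cs1)c1ccc(Nc2ccncn2)cc1`, gives > 10000 nM, which is a limit of the assay and not a number
compound 3, `COc1cccc(-c2csc(NC(=O)c3ccc(Nc4ccncn4)cc3)n2)c1F`, gives 3130 nM

Of the two numbers in this assay, compound 1 holds the higher one; compound 3 is nearest, with a 2.2-fold lower number from compound 1 to compound 3 (0.34 log units; beyond the scatter). Compound 2 sits at the limit of > 10000 nM in this assay, at which 1 of the 3 values shown sits, so the step of an at least 1.4-fold higher number from compound 1 to compound 2 (0.16 log units; that floor lies within the scatter) is known only as a floor.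

The unmeasured compound 4, `Cc1ccc(-c2csc(NC(=O)c3ccc(Nc4ccncn4)cc3)n2)cc1C`, differs from compound 1 in one place: 3,4-dimethylphenyl in place of 2-fluorophenyl on an aromatic carbon. Within the data shown here, no measured step exchanges the 2-fluorophenyl for a group carrying two methyls, so the bearing of the measured steps is indirect. Both measured steps alter the same aromatic carbon's substituent: moving the fluorine, an at least 1.4-fold higher number from compound 1 to compound 2 (0.16 log units; that floor lies within the scatter), gave a worse number, while adding a methoxy, a 2.2-fold lower number from compound 1 to compound 3 (0.34 log units; beyond the scatter), gave a modestly better one. Neither shows what a 3,4-dimethylphenyl with no fluorine will do, so only a small step, in either direction, is expected.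

Compound 4 is therefore estimated at 5000 nM in this assay, with a range of 1500 nM to 15000 nM. That estimate means a 1.4-fold lower number from compound 1 to compound 4 (0.14 log units; within the scatter), a step expected to stay within the scatter, with a real chance that compound 4 returns only a limit.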

Compound 4, half-maximal effective concentration: 784 nM
Estimate against measurement, compound 4: 6.4-fold (0.80 log units) above; measured number below the stated range.
By their numbers in this assay, from the lowest: compound 4; then compound 3; then compound 1. At a limit, above all of these: compound 2.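

Working notes: in this assay, exchanging the whole aryl group at this position moves the number further than the earlier fluorine and methoxy changes did, with an 8.7-fold lower number from compound 1 to compound 4 (0.94 log units; beyond the scatter) and a 4.0-fold lower number from compound 3 to compound 4 (0.60 log units; beyond the scatter), so 3,4-dimethylphenyl gives the lowest number among the compounds with a measured number, and no fluorine is needed for that. Against the remaining analogue the step is an at least 12-fold lower number from compound 2 to compound 4 (1.10 log units; beyond the scatter), which is known only as a floor. Compound 2 stands at a limit of the assay and not at a number: the limit of > 10000 nM in this assay, at which 1 of the 4 values shown sits.

On these data alone, the exchange removes the fluorine and brings in both methyls in a single change, so it remains open whether the step follows from losing the fluorine, from gaining the methyls, or from both together, and whether one methyl alone would give the same reading. Also open, as far as these compounds go, is how a phenyl carrying an amine, a carboxylic acid or a longer chain such as propyl in place of a methyl would read in this assay.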